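Acetyl loss on a shared side chain, twice over

This account rests on a few compounds, and the source may have more. Where it says the series, first, only, none or still open, it means among the compounds named here.

Compound 1 `CC(=O)OC(C)n1cnc2c(Cl)nc(I)nc21` is the only one of the three measured compounds to give a number in a functional assay on SW-620 cells (Homo sapiens) for inhibition; a lower number here means a stronger inhibitor, a higher number a weaker inhibitor: compound 1 gives 3550 nM. Compound 2 `CC(O)n1cnc2c(Cl)nc(I)nc21` carries the change (hydrogen in place of acetyl on an oxygen on a saturated carbon), and in this assay compound 2 gives only a limit, > 500000 nM. That change made a step of an at least 140-fold higher number from compound 1 to compound 2 (2.14 log units; beyond the scatter). Compound 3 `CC(=O)OC(C)n1cnc2c(S)nc(F)nc21` belongs to a different core; the difference between the two cores is not broken down here. In this assay compound 3 gives only a limit, > 500000 nM. Compound 4 `CC(O)n1cnc2c(S)nc(F)nc21` has not yet been measured; it differs from compound 3 by hydrogen in place of acetyl on an oxygen on a saturated carbon, the same change that separates compound 1 from compound 2, at the same place on the side chain.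

Going by the values given here, the one measured instance of this change, from compound 1 to compound 2, went to the limit, and compound 3 already sits at that limit (the limit of > 500000 nM in this assay, at which 2 of the 3 values shown sit). Compound 4 is therefore expected to stay at or beyond that limit, so that the step that the limit leaves unreadable from compound 3 to compound 4 is estimated as no gain at all, resting on the large loss from compound 1 to compound 2 and on the limit value of compound 3. The value of compound 4 in this assay is estimated at 1000000 nM, with a plausible span from 500000 nM to 5000000 nM.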

Compound 4, half-maximal inhibitory concentration: > 500000 nM
Compound 4: only a limit was reported; the forecaster's own chance of this, stated with the estimate: 90%; the middle value lies beyond the limit too.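

In this assay compound 4 gives only a limit, > 500000 nM, and compound 3 likewise gives only a limit, > 500000 nM. The step between compound 3 and compound 4 therefore cannot be read, because both values are limits: the limit of > 500000 nM in this assay, at which 3 of the 4 values shown sit.

The compounds shown leave open whether going from acetoxy to hydroxy changes inhibition at all on the core of compound 3.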